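Naphthyl for phenyl on a quinolone oxadiazole ether

The compounds below may be only part of what the source reports. "The series", "measured", "known", "first", "only" and "open" are said of these compounds alone.

Measured so far:
compound 1, `O=c1c(-c2nnc(COc3ccccc3)o2)cn(C2CC2)c2cc(N3CCNCC3)c(F)cc12`, 48.6 ug/mL;
compound 2, `CCn1cc(-c2nnc(-c3ccc(Nc4ccccc4)cc3)o2)c(=O)c2cc(F)c(N3CCNCC3)cc21`, 88.6 ug/mL.

Both compounds were tested in a functional assay on A549 cells (Homo sapiens) for cytotoxicity, read by MTT assay; on this read-out higher numbers stand for weaker inhibition and lower numbers for stronger inhibition. Compound 1 gives 48.6 ug/mL, the lower of the two numbers, and compound 2 gives 88.6 ug/mL; the gap between them lies within the scatter of repeated measurements, so the two values cannot be told apart with confidence. Compound 2 also differs from compound 1 in several places at once, so it offers no single-point comparison.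

The unmeasured compound 3, `O=c1c(-c2nnc(COc3cccc4ccccc34)o2)cn(C2CC2)c2cc(N3CCNCC3)c(F)cc12`, is a close relative of compound 1. Going by the values given here, the only change is naphthalen-1-yl in place of phenyl on an oxygen on a saturated carbon, on the carbon that links the oxadiazole to the ether oxygen. Among the compounds with values here, no pair of measured compounds shows what this kind of change does here, so there is no measured step to lean on. The step of a 1.3-fold lower number from compound 1 to compound 3 (0.11 log units; within the scatter) is expected to be small and to stay within the scatter, with at most a slight lean toward a lower number. For compound 3 the estimate is 38 ug/mL, with a range from 15 ug/mL to 95 ug/mL.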

Compound 3, half-maximal inhibitory concentration: 96.2 ug/mL
The estimate for compound 3 lay 2.5-fold (0.40 log units) below the measured number; measured number outside the range, above it.
By their numbers in this assay, from the lowest: compounds 1, 2 and 3 (each within the scatter of the next).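

In this assay, going by these compounds alone, naphthalen-1-yl in place of phenyl on an oxygen on a saturated carbon gives a 2.0-fold higher number from compound 1 to compound 3 (0.30 log units; within the scatter), and this is the first comparison that changes one place only. Going from one aromatic ring of carbon to two at this position therefore leaves the number within the scatter, so this pair cannot show that the second ring makes a real difference in either direction, and a repeat measurement could bring the two values closer or push them further apart. Nothing measured here bears on why the step has this size.

On these data alone, it remains open whether naphthalen-2-yl, a plain longer chain or an amine on that same oxygen would move the number beyond the scatter, which would show whether this position matters at all for the cytotoxicity read-out. Compound 2 differs from compound 1 and compound 3 in several places at once, so its steps to them cannot be read, and it cannot help settle the question.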